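Azetidin-3-yl Added at the Hydroxymethyl Carbon

The source may hold more compounds than are shown below. What is called first, only, known or untested is meant among the compounds shown, and "the series" means these compounds.

Compound 1 `CN1CCN(CCCC(O)c2ccc(-c3ccc(N4C[C@H](Cn5ccnn5)OC4=O)cc3F)cn2)CC1`: 41000 nM
Compound 2 `O=C1O[C@@H](Cn2ccnn2)CN1c1ccc(-c2ccc(CO)nc2)c(F)c1`: 4800 nM
Compound 3 `COCc1ccc(-c2ccc(N3C[C@H](Cn4ccnn4)OC3=O)cc2F)cn1`: 1700 nM

In an assay for inhibition of Amine oxidase [flavin-containing] A (Homo sapiens) (on this read-out lower numbers stand for stronger inhibition and higher numbers for weaker inhibition), compound 2 stands second highest of the three numbers: compound 3 lies nearest, with a 2.8-fold lower number from compound 2 to compound 3 (0.45 log units; beyond the scatter), and compound 1 lies furthest, with an 8.5-fold lower number from compound 1 to compound 2 (0.93 log units; beyond the scatter). Compound 4 `O=C1O[C@@H](Cn2ccnn2)CN1c1ccc(-c2ccc(C(O)C3CNC3)nc2)c(F)c1` differs from compound 2 by azetidin-3-yl in place of hydrogen on a saturated chain carbon bound to an aromatic carbon and an oxygen on a saturated carbon. Going by the values given here, the step that bears on this change is the one from compound 1 to compound 2, where removing a substituent from the same saturated chain carbon lowered the number by a modest amount. Going the other way, compound 4 is therefore expected to show a modestly higher number than compound 2, a 2.5-fold higher number from compound 2 to compound 4 (0.40 log units; beyond the scatter). Compound 4 is estimated at 12000 nM, in a range from 4000 nM to 40000 nM.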

Compound 4, inhibition constant: 58000 nM
Beside the measured number, compound 4's estimate is 4.8-fold (0.68 log units) below it, outside the stated range (above it).
By their numbers in this assay, from the lowest: compound 3; then compound 2; then compounds 1 and 4 (each within the scatter of the next).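

Placing azetidin-3-yl on the saturated chain carbon bound to an aromatic carbon and an oxygen costs heavily (a 12-fold higher number from compound 2 to compound 4 (1.08 log units; beyond the scatter)), so even this small ring is poorly tolerated at that carbon. Exchanging it for the much longer 3-(4-methylpiperazin-1-yl)propyl makes no difference beyond the scatter (a 1.4-fold higher number from compound 1 to compound 4 (0.15 log units; within the scatter)). The gap to the methoxymethyl compound is wider still (a 34-fold higher number from compound 3 to compound 4 (1.53 log units; beyond the scatter)). Going by these compounds, whether a methyl group alone on that carbon, which carries no amine, would give the same loss stays open. Nothing available explains these steps.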